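Chalcone series: bromo to fluoro on the benzyl ring

A few compounds are considered here, and "the series" means these few. Any claim that something is new, unique, unknown or untested is made for them only; others in the source may bear on it.

Compound 3 `O=C(/C=C/c1ccc(OCc2cn(Cc3cccc(Br)c3)nn2)cc1)c1ccc(Br)cc1` gives 25% in a functional assay on HepG2 cells (Homo sapiens) for inhibition, read by MTT assay, with a stated time of 48 h, tested at 10 uM; a higher number here means more inhibition of growth at the concentration tested, a lower number less inhibition of growth. Among the three numbers known it stands second highest; the nearest is compound 1 `C#CCOc1ccc(/C=C/C(=O)c2ccc(Br)cc2)cc1` with 22%, the furthest compound 2 `O=C(/C=C/c1ccc(OCc2cn(Cc3ccccc3Br)nn2)cc1)c1ccc(Br)cc1` with 34%, and both gaps lie within the scatter. Compound 4 `O=C(/C=C/c1ccc(OCc2cn(Cc3cccc(F)c3)nn2)cc1)c1ccc(Br)cc1` is not yet measured; it differs from compound 3 by fluoro in place of bromo on an aromatic carbon. Among the compounds with values here, no measured step exchanges one halogen for another. Within the data shown here, the only step in this region of the structure is a number 9 percentage points lower from compound 2 to compound 3 (within the scatter), a change within the scatter, and compound 1, the smallest of the three, also sits within the scatter of compound 3. The steps seen so far give no ground for expecting a move beyond the scatter in this assay. For compound 4 the expected step is no change at the digits printed from compound 3 to compound 4 (within the scatter), a change within the scatter. The estimate for compound 4 in this assay is 25%, with a range from 10% to 40%.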

Compound 4, percent growth inhibition at one concentration: 34%
For compound 4 the middle estimate is 9 percentage points below the measured one; the range from low to high includes it.
By their numbers in this assay, from the lowest: compounds 1, 3, 2 and 4 (each within the scatter of the next, the first and the last beyond it).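

Within the data shown here, the exchange of 3-bromobenzyl for 3-fluorobenzyl is the first halogen-for-halogen step, and in this assay it reads a number 9 percentage points higher from compound 3 to compound 4 (within the scatter), so at this place on the ring, bromo and fluoro cannot be told apart in this read-out. The step that also moves the halogen on the ring, 3-fluorophenyl in place of 2-bromophenyl, reads no change at the digits printed from compound 2 to compound 4 (within the scatter), and it too stays inside the scatter. The data offer no explanation for the size of either step.

On these data alone, whether a group other than a halogen at this place, such as an amine, a carboxylic acid or a longer chain, would give a step beyond the scatter remains open. As far as these compounds go, the effect of fluoro alone at other places on this ring also remains open.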